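This account rests on a few compounds, and the source may have more. Where it says the series, first, only, none or still open, it means among the compounds named here.

Measured so far:
- compound 1 `O=c1[nH]/c(=N\OCCCc2ccc(F)cc2)ccn1[C@@H]1O[C@H](COP(=O)(O)OP(=O)(O)OP(=O)(O)O)[C@@H](O)[C@H]1O`: 105 nM
- compound 2 `O=c1[nH]/c(=N\OCCCc2cccc(I)c2)ccn1[C@@H]1O[C@H](COP(=O)(O)OP(=O)(O)OP(=O)(O)O)[C@@H](O)[C@H]1O`: 114 nM
- compound 3 `COc1ccc(CCCO/N=c2/ccn([C@@H]3O[C@H](COP(=O)(O)OP(=O)(O)OP(=O)(O)O)[C@@H](O)[C@H]3O)c(=O)[nH]2)cc1`: 23 nM

In a functional assay on 1321-N1 cells for agonist activity at P2Y purinoceptor 4 (Homo sapiens), read by scintillation counting and inositol phosphate accumulation (a higher number here means that more compound is needed for the effect, a lower number that less compound is needed), compound 3 gives the lowest of the three numbers; the nearest is compound 1 with a 4.6-fold lower number from compound 1 to compound 3 (0.66 log units; beyond the scatter), the furthest compound 2 with a 5.0-fold lower number from compound 2 to compound 3 (0.70 log units; beyond the scatter). Compound 1 and compound 2 sit close together, with a 1.1-fold higher number from compound 1 to compound 2 (0.04 log units; within the scatter).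

Compound 4 `O=c1[nH]/c(=N\OCCCc2ccc3ccccc3c2)ccn1[C@@H]1O[C@H](COP(=O)(O)OP(=O)(O)OP(=O)(O)O)[C@@H](O)[C@H]1O` differs from compound 3 in one place: naphthalen-2-yl in place of 4-methoxyphenyl on a saturated chain carbon, three bonds along the chain from an oxygen on an unsaturated carbon.

The two steps that bear on this change are those leading into compound 3, a 4.6-fold lower number from compound 1 to compound 3 (0.66 log units; beyond the scatter) and a 5.0-fold lower number from compound 2 to compound 3 (0.70 log units; beyond the scatter), each a modest shift from a halogen-bearing phenyl to the methoxy-bearing one. Compound 4 carries neither the methoxy nor a halogen, so the number is expected to move back toward the halogen-bearing compounds, giving an estimated step of a 3.0-fold higher number from compound 3 to compound 4 (0.48 log units; beyond the scatter) in this assay. For compound 4 the estimate in this assay is 70 nM, expected to fall between 25 nM and 200 nM.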

Compound 4, half-maximal effective concentration: 128 nM
Compound 4: middle estimate off by 1.8-fold (0.26 log units), on the low side; measured number inside the range.
By their numbers in this assay, from the lowest: compound 3; then compounds 1, 2 and 4 (each within the scatter of the next).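

In this assay, the change to naphthalen-2-yl, with its two six-membered aromatic rings of carbon only, gives a 5.6-fold higher number from compound 3 to compound 4 (0.75 log units; beyond the scatter), so this larger group does not keep the low number seen with 4-methoxyphenyl. The new number instead sits with those of the halogen-bearing compounds, at a 1.1-fold higher number from compound 2 to compound 4 (0.05 log units; within the scatter) and a 1.2-fold higher number from compound 1 to compound 4 (0.09 log units; within the scatter), which leaves the methoxy-bearing compound 3 alone among the four at the low end. No measurement at hand explains why this one group stands apart.

What remains open is whether the oxygen of the methoxy group matters, or the whole group, since only one methoxy-bearing compound is shown. A hydroxy or ethoxy group on the phenyl ring, or a plain unsubstituted phenyl, would help separate these possibilities.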